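Cyano in place of tert-butoxycarbonyl on an aromatic carbon

This account rests on a few compounds, and the source may have more. Where it says the series, first, only, none or still open, it means among the compounds named here.

Going by the values given here, in a functional assay on QG-56 cells (Homo sapiens) for antiproliferative activity (on this read-out lower numbers stand for stronger inhibition and higher numbers for weaker inhibition), compound 3 `Cn1cncc1C(O)(c1ccc(C(=O)OC(C)(C)C)cc1)c1cc2cc([N+](=O)[O-])cc(-c3ccccc3)c2o1` gives 6250 nM as the highest of the three numbers measured so far. Compound 4 `Cn1cncc1C(O)(c1ccc(C#N)cc1)c1cc2cc([N+](=O)[O-])cc(-c3ccccc3)c2o1` differs from it by a single exchange cyano in place of tert-butoxycarbonyl on an aromatic carbon with cyano in place of tert-butoxycarbonyl on an aromatic carbon. Among the compounds with values here, no measured pair isolates this change, but compound 1 `Cn1cncc1C(O)(c1ccc(C#N)cc1)c1cc2cc([N+](=O)[O-])cc(-c3ccccc3F)c2o1` and compound 2 `Cn1cncc1C(O)(c1ccc(C#N)cc1)c1cc2cc(C#N)cc(-c3ccccc3)c2o1` both carry cyano in that place. A large fall in the number is expected, since compound 1 gives 89.5 nM and compound 2 gives 14.5 nM in this assay despite their other differences from compound 3. The expected step is a 160-fold lower number from compound 3 to compound 4 (2.19 log units; beyond the scatter) and it is estimated to lie well beyond the scatter. Compound 4 is estimated at 40 nM with an expected range from 10 nM to 160 nM in this measurement.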

Compound 4, half-maximal inhibitory concentration: 1480 nM
Compound 4: middle estimate off by 37-fold (1.57 log units), on the low side; measured number outside the range, above it.
By their numbers in this assay, from the lowest: compound 2; then compound 1; then compound 4; then compound 3.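

In this assay the exchange at this position alone gives a 4.2-fold lower number from compound 3 to compound 4 (0.63 log units; beyond the scatter) and so accounts for only part of the distance between compound 3 and the two other cyano compounds. Larger steps come from the other places: a 100-fold higher number from compound 2 to compound 4 (2.01 log units; beyond the scatter) goes with nitro in place of cyano on an aromatic carbon, and a 17-fold higher number from compound 1 to compound 4 (1.22 log units; beyond the scatter) goes with hydrogen in place of fluoro on an aromatic carbon. Nothing measured here explains these steps. Going by these compounds, whether an amine or a carboxylic acid at this position would give a lower number than cyano stays open, as does whether the fluoro and cyano exchanges add up in one compound.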